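Adding a Methoxy Group to the Oxime Phenyl

The compounds below may be only part of what the source reports. "The series", "measured", "known", "first", "only" and "open" are said of these compounds alone.

Compound 3 `CO/N=C(/COc1ccc2c(=O)cc(-c3ccccc3)oc2c1)c1ccccc1` was tested in a functional assay on SK-HEP1 cells (Homo sapiens) for antiproliferative activity (a higher number here means a weaker inhibitor of growth, a lower number a stronger inhibitor of growth), and gives 2000000 nM. Compound 1 `CO/N=C(\C)COc1ccc2c(=O)cc(-c3ccccc3)oc2c1` gives 2000000 nM in this assay, so the two stand level and together at the low end of the three numbers. Compound 2 `COc1ccc(/C(COc2ccc3c(=O)cc(-c4ccccc4)oc3c2)=N\O)cc1` gives 5600000 nM, a higher number than compound 3. Within the data shown here, the one step measured along this series, no change at the digits printed from compound 1 to compound 3 (within the scatter), shows that replacing methyl with phenyl on the carbon double-bonded to nitrogen left the number unchanged within the scatter. Compound 4 `CO/N=C(/COc1ccc2c(=O)cc(-c3ccccc3)oc2c1)c1ccc(OC)cc1` differs from compound 3 only in one place: methoxy in place of hydrogen on an aromatic carbon, which seen one bond further out reads phenyl to 4-methoxyphenyl. Among the measured compounds shown here, no measured step isolates this particular change; compound 2 also carries a methoxyphenyl but differs from compound 3 elsewhere as well, so its value cannot be read as a step. With nothing pointing to a clear shift, compound 4 is expected to stay close to compound 3, giving an estimated 1.3-fold higher number from compound 3 to compound 4 (0.10 log units; within the scatter). Compound 4 is therefore estimated at 2500000 nM, within a range of 1000000 nM to 7000000 nM.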

Compound 4, concentration for 50% growth inhibition: 4800000 nM
For compound 4 the middle estimate is 1.9-fold (0.28 log units) below the measured one; measured number inside the range.
By their numbers in this assay, from the lowest: compounds 1 and 3 (each within the scatter of the next); then compounds 4 and 2 (each within the scatter of the next).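

On the ring of compound 3, methoxy in place of hydrogen, para to a large group, gives a weaker inhibitor of growth in this assay (a 2.4-fold higher number from compound 3 to compound 4 (0.38 log units; beyond the scatter)), a modest step but one beyond the scatter. Phenyl in place of methyl had left the number unchanged, whereas 4-methoxyphenyl in place of methyl does shift it (a 2.4-fold higher number from compound 1 to compound 4 (0.38 log units; beyond the scatter)), so the group on this carbon can matter once it carries the methoxy. With 4-methoxyphenyl kept, methyl in place of hydrogen on the oxime oxygen stays within the scatter (a 1.2-fold lower number from compound 2 to compound 4 (0.07 log units; within the scatter)), so compound 2 and compound 4 cannot be told apart here.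

Nothing available explains why the methoxy shifts the number. From the compounds shown here alone, whether a smaller group such as fluorine, or an amine or a longer alkoxy chain, at this same place would shift it further, or reverse the step, stays open.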